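Pyrazole isomer swap on an inactive core

The compounds below may be only part of what the source reports. "The series", "measured", "known", "first", "only" and "open" are said of these compounds alone.

Compound 1 `c1cc(-c2cn[nH]c2)c2c(c1)C(c1ncc[nH]1)CC2` is the starting point. In a functional assay on CHO cells for agonist activity at Alpha-1B adrenergic receptor (Homo sapiens), read by FLIPR and calcium flux (a lower number here means that less compound is needed, a higher number that more compound is needed for the effect), compound 1 gives > 10000 nM, which is a limit of the assay and not a number. Compound 2 `c1ccc2c(c1)CCC2c1ncc[nH]1` gives in this assay > 10000 nM, again a limit. The step that the two limits leave unreadable from compound 1 to compound 2 is therefore unreadable, as both values sit at the limit of > 10000 nM in this assay, at which 2 of the 2 values shown sit. Compound 3 `c1cc(-c2ccn[nH]2)c2c(c1)C(c1ncc[nH]1)CC2` differs from compound 1 by 1H-pyrazol-5-yl in place of 1H-pyrazol-4-yl on an aromatic carbon. For the measured compounds named here, no measured step bears readably on this change, and compound 1 rests at a limit, so compound 3 is expected to remain near that limit in this assay, estimated at 20000 nM within 5000 nM to 100000 nM, a step that the limit leaves unreadable from compound 1 to compound 3.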

Compound 3, half-maximal effective concentration: 600 nM
Estimate against measurement, compound 3: 33-fold (1.52 log units) above; the whole stated range lies above it.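

In this assay, how the pyrazole is joined to the shared core decides whether a response can be read: 1H-pyrazol-5-yl in place of 1H-pyrazol-4-yl gives an at least 16-fold lower number from compound 1 to compound 3 (1.22 log units; beyond the scatter). Placing 1H-pyrazol-5-yl on the aromatic carbon of the bare core gives an at least 16-fold lower number from compound 2 to compound 3 (1.22 log units; beyond the scatter). Compound 3 thus gives the first value in the series that is a number and not a limit: the limit of > 10000 nM in this assay, at which 2 of the 3 values shown sit.

From the compounds shown here alone, the true size of both steps remains open. Also open, going by these compounds, is whether an amine or a carboxylic acid on this aromatic carbon would keep the response.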